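Removing the Methylpiperazine From a Hydroxamic Acid Chalcone

The source may hold more compounds than are shown below. What is called first, only, known or untested is meant among the compounds shown, and "the series" means these compounds.

Of the compounds shown here, three have so far been measured in a functional assay on K562 cells (Homo sapiens) for antiproliferative activity, read by MTT assay, with a stated time of 72 h; on this read-out lower numbers stand for stronger inhibition and higher numbers for weaker inhibition. Compound 1 `CN1CCN(c2ccccc2C(=O)/C=C/c2ccc(/C=C/C(=O)NO)cc2)CC1` gives 1600 nM. Compound 2 `CN1CCN(c2cccc(C(=O)/C=C/c3ccc(/C=C/C(=O)NO)nc3)c2)CC1` gives 360 nM, and compound 3 `CN1CCN(c2cccc(C(=O)/C=C/c3cccc(/C=C/C(=O)NO)n3)c2)CC1` gives 110 nM. Compound 2 therefore holds the second highest of the three numbers: its nearest neighbour is compound 3, whose number is lower by a gap beyond the usual scatter, while compound 1 sits further off in the other direction, again beyond the scatter.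

Compound 4 `O=C(/C=C/c1ccc(/C=C/C(=O)c2ccccc2)cn1)NO` has not yet been measured. It differs from compound 2 in a single place: hydrogen in place of 4-methylpiperazin-1-yl on an aromatic carbon

Among the compounds with values here, no pair of measured compounds shows this change, so no direct guide exists. The group that leaves is a sizeable piece of the molecule, and its loss is expected to cost potency in this assay by a moderate step toward a higher number, beyond the scatter. Compound 4 is thus expected to give about 1500 nM, within a range from 500 nM to 5000 nM. The estimated step of a 4.2-fold higher number from compound 2 to compound 4 (0.62 log units; beyond the scatter) points toward weaker inhibition.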

Compound 4, half-maximal inhibitory concentration: 690 nM
The estimate for compound 4 lay 2.2-fold (0.34 log units) above the measured number; measured number inside the range.
By their numbers in this assay, from the lowest: compound 3; then compounds 2 and 4 (each within the scatter of the next); then compound 1.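

In this assay, putting hydrogen in place of 4-methylpiperazin-1-yl on an aromatic carbon gives a 1.9-fold higher number from compound 2 to compound 4 (0.28 log units; within the scatter). The numbers for the two compounds therefore cannot be told apart, which shows that this whole group, with its six-membered ring and two nitrogens, can leave this position without a measurable cost in this read-out. Nothing at hand explains why the loss of so large a group leaves so little trace.

Going by these compounds, whether other groups at this aromatic carbon, such as a dimethylamino group or a carboxylic acid, would also read the same as hydrogen remains open. On these data alone, it is equally open whether taking away 4-methylpiperazin-1-yl from the core of compound 3 would leave its number within the scatter.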